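A few compounds are considered here, and "the series" means these few. Any claim that something is new, unique, unknown or untested is made for them only; others in the source may bear on it.

Compound 1 `CCc1nc2nc(C(F)(F)F)ccc2c(=O)n1Cc1cn(CC(=O)Nc2ccccc2)nn1` and compound 2 `CCCCCCCCCCn1cc(Cn2c(CC)nc3nc(C(F)(F)F)ccc3c2=O)nn1` share one core and differ in a single place. In a functional assay on MDA-MB-231 cells (Homo sapiens) for antiproliferative activity, read by sulforhodamine B assay, with a stated time of 48 h (a higher number here means a weaker inhibitor of growth, a lower number a stronger inhibitor of growth), compound 1 gives 1700 nM, while compound 2 gives 2210 nM. The change that separates them is nonyl in place of phenylcarbamoyl on a saturated chain carbon bound to an aromatic nitrogen and the step it made was a 1.3-fold higher number from compound 1 to compound 2 (0.11 log units; within the scatter), so the two numbers cannot be told apart in order.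

Compound 3 `O=C(Cn1cc(COc2nc(-c3ccccc3)nc3nc(C(F)(F)F)ccc23)nn1)Nc1ccccc1` is built on a different core; the difference between the two cores is not broken down here. In this assay compound 3 gives 650 nM, the lowest of the three numbers, and its gaps to compound 1 and to compound 2 both lie beyond the scatter.

Compound 4 `CCCCCCCCCCn1cc(COc2nc(-c3ccccc3)nc3nc(C(F)(F)F)ccc23)nn1` has not yet been measured. It stands to compound 3 exactly as compound 2 stands to compound 1: the change is nonyl in place of phenylcarbamoyl on a saturated chain carbon bound to an aromatic nitrogen, made at the same place, so it is the same change rather than merely the same kind. Among the measured compounds shown here, the only guide to its effect is the single earlier step, and that one lay within the scatter. On that basis the step from compound 3 is expected to be small, a 1.3-fold higher number from compound 3 to compound 4 (0.12 log units; within the scatter), because the same change in the first pair gave a 1.3-fold higher number from compound 1 to compound 2 (0.11 log units; within the scatter). For the measured compounds named here, compound 4 is therefore expected to give about 850 nM in this assay, with a plausible range from 400 nM to 1900 nM, the width reflecting that the core differs and only one precedent exists.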

Compound 4, concentration for 50% growth inhibition: 1050 nM
For compound 4 the middle estimate is 1.2-fold (0.09 log units) below the measured one, within the range that was stated.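

In this assay, putting nonyl in place of phenylcarbamoyl on a saturated chain carbon bound to an aromatic nitrogen gives a 1.6-fold higher number from compound 3 to compound 4 (0.21 log units; within the scatter), and set beside the earlier step, the change carries over from one core to the other without a detectable difference: the same change on two cores in this assay, a 1.3-fold higher number (0.11 log units; within the scatter) from compound 1 to compound 2 and a 1.6-fold higher number (0.21 log units; within the scatter) from compound 3 to compound 4, 1.2-fold (0.09 log units) apart, within the scatter of two such steps. On both cores shown, the compound with the nonyl group and the compound with the phenylcarbamoyl group cannot be told apart in this assay, even though the exchange removes an aromatic ring, the amide hydrogen and the carbonyl from that side chain. Among the compounds shown here, this rests on only two pairs, so it shows agreement between these two cores alone and does not show that the change would stay this small on any other core or in any other cell line.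

The compounds shown leave open whether a shorter chain, a longer chain, or a chain ending in an amine or a carboxylic acid would fit the same picture at this place. They also leave open whether a phenyl ring bearing a fluorine or methoxy group on the carbamoyl side would separate from the unsubstituted one on either core.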